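The source may report more compounds than this note shows. Statements on the series, on what has been measured and on what is new or still open speak of the compounds shown alone.

Compound 1 (`CCOc1cc(C(C)(C)C)ccc1C1=NC(c2ccc(Cl)cc2)C(c2ccc(Cl)cc2)N1C(=O)NCCCCCCCC(=O)NO`) gives 7920 nM in a functional assay on MCF7 cells (Homo sapiens) for antiproliferative activity, read by CCK-8 assay, with a stated time of 72 h; on this read-out higher numbers stand for weaker inhibition and lower numbers for stronger inhibition. Compound 2 (`CCOc1cc(C(C)(C)C)ccc1C1=NC(c2ccc(Cl)cc2)C(c2ccc(Cl)cc2)N1C(=O)NCCCCCC(=O)Nc1ccccc1N`) gives > 100000 nM in this assay, and this is a limit of the assay and not a number. Compound 3 (`CCOc1cc(C(C)(C)C)ccc1C1=NC(c2ccc(Cl)cc2)C(c2ccc(Cl)cc2)N1C(=O)NCCCCC(=O)Nc1ccccc1N`) keeps the shared core and the (2-aminophenyl)carbamoyl end, and it differs from compound 2 in one place: (2-aminophenyl)carbamoyl in place of ((2-aminophenyl)carbamoyl)methyl on a saturated chain carbon, four bonds along the chain from an amide-type nitrogen. In other words, 2-((2-aminophenyl)carbamoyl)ethyl gives way to ((2-aminophenyl)carbamoyl)methyl. Among the measured compounds shown here, only one measured step bears on this change, an at least 12-fold higher number from compound 1 to compound 2 (1.10 log units; beyond the scatter). That step is large, but it replaces the hydroxycarbamoyl end as well, so it gives no measured size for a change in the chain alone. Compound 2 also offers only a limit as a starting point, with no number to move from. No step beyond the scatter is therefore expected in this assay, and a report at the limit again seems likely. The expected step is a number no higher from compound 2 to compound 3 (the limit leaves the size open). For compound 3 the estimated value is 100000 nM, with an expected range from 40000 nM to 150000 nM.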

Compound 3, half-maximal inhibitory concentration: 29100 nM
Estimate against measurement, compound 3: 3.4-fold (0.54 log units) above, and the stated range ends above it.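

Moving from 2-((2-aminophenyl)carbamoyl)ethyl to ((2-aminophenyl)carbamoyl)methyl gives an at least 3.4-fold lower number from compound 2 to compound 3 (0.53 log units; beyond the scatter) in this assay, so the chain alone moves the read-out while the (2-aminophenyl)carbamoyl end stays in place, which the step between the first two compounds could not show. Compound 2 stands at a limit of the assay and not at a number, so the step gives only a minimum size: the limit of > 100000 nM in this assay, at which 1 of the 3 values shown sits. The shortened chain does not close the gap to the hydroxycarbamoyl end, since the comparison with compound 1 is a 3.7-fold higher number from compound 1 to compound 3 (0.57 log units; beyond the scatter), and that step changes both the chain and the end group.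

With only these two chains carrying the (2-aminophenyl)carbamoyl end, the compounds shown do not tell whether a still shorter chain would lower the number further or whether compound 3 sits near the best chain for this end. They also leave open how a carboxylic acid in place of the (2-aminophenyl)carbamoyl end, or a hydroxycarbamoyl end on the chain of compound 3, would read in this assay.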